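The source may hold more compounds than are shown below. What is called first, only, known or untested is meant among the compounds shown, and "the series" means these compounds.

Measured compounds:
compound 1 `CCCCC/C=C\C/C=C\CCCCCCCC1(O)CC(=O)c2c(O)cc(O)cc2O1`, 6790 nM
compound 2 `CCCCC/C=C\C/C=C\CCCCCCCc1cc(=O)c2c(O)c(C)c(OCOC)c(C)c2o1`, 16100 nM
compound 3 `CCCCC/C=C\C/C=C\CCCCCCCc1cc(=O)c2c(O)cc(O)cc2o1`, 6790 nM

All three were tested in a functional assay on MDA-MB-231 cells (Homo sapiens) for antiproliferative activity, read by MTT assay; a higher number here means a weaker inhibitor, a lower number a stronger inhibitor. Compound 1 and compound 3 give the same number at the digits shown, so they lie within the scatter of each other and together hold the lowest numbers of the three. Compound 2 gives a higher number than compound 1, a gap beyond the scatter. Among the compounds with values here, no pair of measured compounds differs in a single place, so no measured step is available. Compound 4 `CCCCC/C=C\C/C=C\CCCCCCCC1(O)CC(=O)c2c(O)cc(OCOC)cc2O1` differs from compound 1 in one place: methoxymethyl in place of hydrogen on an oxygen on an aromatic ring. Compound 2 also carries a methoxymethyl on an oxygen on an aromatic ring, yet it differs from compound 1 in further places, so its higher number is only a faint hint. In this assay the step is expected to be a 1.3-fold higher number from compound 1 to compound 4 (0.12 log units; within the scatter), a small rise that may stay within the scatter. Compound 4 is estimated at 9000 nM, with a range from 4000 nM to 20000 nM.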

Compound 4, half-maximal inhibitory concentration: 16100 nM
Compound 4: the middle estimate sits 1.8-fold (0.25 log units) below what was measured; the measured number falls inside the stated range.
By their numbers in this assay, from the lowest: compounds 1 and 3 (each within the scatter of the next); then compounds 2 and 4 (each within the scatter of the next).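

Within the data shown here, replacing hydroxy with methoxymethoxy on the aromatic ring gives a 2.4-fold higher number from compound 1 to compound 4 (0.37 log units; beyond the scatter) in this assay and is the first measured step here that changes one place only. It shows that this oxygen is sensitive to what it carries: adding methoxymethyl to it gives a weaker inhibitor, though the step is modest. Nothing measured here gives a reason for this loss.

From the compounds shown here alone, whether a simple methyl or a larger benzyl on this oxygen would give a similar rise remains open. So does whether the same change at the other ring hydroxy would match it.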